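Cytotoxicity notes: ether change on compound 3

This account rests on a few compounds, and the source may have more. Where it says the series, first, only, none or still open, it means among the compounds named here.

In a toxicity assay on THP-1 cells (Homo sapiens) for cytotoxicity, read by MTT assay, with a stated time of 72 h (on this read-out lower numbers stand for an effect already at smaller amounts and higher numbers for an effect only at larger amounts of compound), compound 1 `Cc1cccc(Cn2cc(/C=N/NC(N)=S)c3ccccc32)c1` gives 32000 nM, and compound 2 `NC(=S)N/N=C/c1cn(CCCc2ccccc2)c2ccccc12` gives 30000 nM. Within the data shown here, the only step between measured compounds that differ in one place, a 1.1-fold lower number from compound 1 to compound 2 (0.03 log units; within the scatter), concerns the group on a saturated chain carbon bound to an aromatic nitrogen and does not touch the site changed here. Compound 3 `CCOc1ccc(/C=N/NC(N)=S)c2ccccc12` reaches only a limit of the assay, > 200000 nM, not a number. Compound 4 `COCOc1ccc(/C=N/NC(N)=S)c2ccccc12` differs from compound 3 by methoxy in place of methyl on a saturated chain carbon bound to an oxygen on an aromatic ring. Among the measured compounds shown here, no measured step addresses this change; the standing of compound 3 rests on (the limit of > 200000 nM in this assay, at which 1 of the 3 values shown sits). For compound 4 the expected step is a number no higher from compound 3 to compound 4 (the limit leaves the size open), none beyond the scatter. Compound 4 is therefore estimated at 200000 nM, between 100000 nM and 400000 nM, most likely again only a limit.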

Compound 4, half-maximal effective concentration: > 200000 nM
Compound 4: no number, only a limit (the forecaster's own chance of this, stated with the estimate: 70%); the middle value lies on the limit itself.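

Compound 3 and compound 4 both reach only a limit in this assay, not a number, so no step can be read between them: the limit of > 200000 nM in this assay, at which 2 of the 4 values shown sit.

On these data alone, whether methoxy in place of methyl at this place shifts the read-out at all remains open.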